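The source may report more compounds than this note shows. Statements on the series, on what has been measured and on what is new or still open speak of the compounds shown alone.

Measured in an ADME assay on GES1 cells (Homo sapiens) for inhibition, read by MTT assay, with a stated time of 72 h; a lower number here means a stronger inhibitor, a higher number a weaker inhibitor:
- compound 1 `Cc1cc(Nc2cc(-c3ccccc3)[nH]n2)n2nc(SCc3cccc4ccccc34)nc2n1`: 36300 nM
- compound 2 `Cc1cc(Nc2ccn(Cc3csc4ccc(Cl)cc34)n2)n2nc(SCc3ccc(Br)cc3)nc2n1`: 31400 nM
- compound 3 `Cc1nc2nc(SCc3ccc(Cl)cc3)nn2c(Nc2cc(-c3ccccc3)[nH]n2)c1C`: 47200 nM

In this assay, compound 2 gives 31400 nM, which lies within the scatter of both other measured compounds. Compound 1 gives 36300 nM and compound 3 gives 47200 nM, so the three values cannot be ranked.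

The compound still awaiting measurement is compound 4 `Cc1cc(Nc2ccn(Cc3ccc(C(F)(F)F)cc3)n2)n2nc(SCc3ccc(Br)cc3)nc2n1`, and its structure departs from that of compound 2 in a single place: 4-(trifluoromethyl)phenyl in place of 5-chloro-1-benzothiophen-3-yl on a saturated chain carbon bound to an aromatic nitrogen. It carries 4-(trifluoromethyl)phenyl in place of 5-chloro-1-benzothiophen-3-yl on a saturated chain carbon bound to an aromatic nitrogen.

Going by the values given here, no two measured compounds differ in only one place, so the data hold no direct precedent for this change. Among the compounds with values here, the only guide is the narrow spread of the three values, which holds even though compound 1 and compound 3 differ from compound 2 in more than one place. A step beyond the scatter in this assay is therefore not expected, in either direction. The estimate amounts to a 1.2-fold higher number from compound 2 to compound 4 (0.08 log units; within the scatter), an expected shift that stays within the scatter. The estimated value for compound 4 is 38000 nM, with an expected range from 17000 nM to 80000 nM.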

Compound 4, half-maximal inhibitory concentration: 30200 nM
Estimate against measurement, compound 4: 1.3-fold (0.10 log units) above, within the range that was stated.
By their numbers in this assay, from the lowest: compounds 4, 2, 1 and 3 (each within the scatter of the next).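

In this assay, exchanging the (5-chloro-1-benzothiophen-3-yl)methyl group of compound 2 for 4-(trifluoromethyl)benzyl gives a 1.0-fold lower number from compound 2 to compound 4 (0.02 log units; within the scatter), and this is the only pair shown that differs in one place. On a saturated chain carbon bound to an aromatic nitrogen, a group with a five-membered and a six-membered aromatic ring, sulfur and chlorine therefore reads the same in this assay as a group with one six-membered ring and trifluoromethyl, at an equal count of heavy atoms. No measured property of either group is available to explain this result.

The compounds shown leave open whether an amine or a carboxylic acid on the benzyl ring, or a longer chain in place of the benzyl group, would also stay within the scatter in this assay. They also leave open whether the same exchange would read alike with a group other than 4-bromobenzyl on the sulfur, as this single pair carries only that one.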